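Trading a sulfonyl linker for a plain hydroxybutyl chain

A few compounds are considered here, and "the series" means these few. Any claim that something is new, unique, unknown or untested is made for them only; others in the source may bear on it.

Compound 1 `CC(C)Cn1c(=O)n(C)c(=O)c2nc(SCCCCO)c(Cc3cccc4ccccc34)nc21`: 669 nM
Compound 2 `CC(C)Cn1c(=O)n(C)c(=O)c2nc(S(=O)(=O)CCCO)c(Cc3cccc4ccccc34)nc21`: "not determined" (no result reported)

In an assay on MCF7 cells for inhibition of Monocarboxylate transporter 1 (Homo sapiens), read by scintillation counting, with a stated time of 10 min (a higher number here means a weaker inhibitor, a lower number a stronger inhibitor), compound 1 gives 669 nM. Compound 2 bears a (3-hydroxypropyl)sulfonyl group on the shared core, yet in this assay compound 2 gives "not determined" (no result reported), so compound 2 stands nowhere on the scale. Compound 3 `CC(C)Cn1c(=O)n(C)c(=O)c2nc(CCCCO)c(Cc3cccc4ccccc34)nc21` differs from compound 2 in one place: 4-hydroxybutyl in place of (3-hydroxypropyl)sulfonyl on an aromatic carbon. For the measured compounds named here, with compound 2 unmeasured, no step size can be stated; the only anchor is compound 1, whose hydroxybutyl chain hangs from the core through a sulfur link rather than directly. For compound 3 the expected value in this assay is 1000 nM, within a range from 300 nM to 4000 nM.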

Compound 3, half-maximal inhibitory concentration: > 2000 nM
Compound 3: a limit, no number (the forecaster's own chance of this, stated with the estimate: 10%); middle value at least 2.0-fold (0.30 log units) from the limit.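

Joining the hydroxybutyl chain directly to the shared core, without the sulfur link, gives an at least 2.9-fold higher number from compound 1 to compound 3 (0.47 log units; beyond the scatter) in this assay and so provides the first readable step at this position: the sulfur link counts, not the chain alone. The step from compound 2 to compound 3 cannot be read. The result for compound 3 is a limit, not a number: the limit of > 2000 nM in this assay, at which 1 of the 3 values shown sits.

As far as these compounds go, the full size of this step stays open. So does how an amine, a carboxylic acid or a longer chain on this aromatic carbon would compare.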